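This account rests on a few compounds, and the source may have more. Where it says the series, first, only, none or still open, it means among the compounds named here.

Compound 1 `Cc1ncnc2c1c(I)cn2[C@@H]1O[C@H](CO)[C@@H](O)[C@H]1O`: 12600 nM
Compound 2 `CNc1ncnc2c1c(I)cn2[C@@H]1O[C@H](CO)[C@@H](O)[C@H]1O`, a limit of the assay: > 20000 nM

In a functional assay on CEM-DNR-bulk cells (Homo sapiens), read by MTT assay, with a stated time of 72 h (on this read-out higher numbers stand for weaker inhibition and lower numbers for stronger inhibition), compound 2 reaches only a limit, > 20000 nM, so no number is known for it. Compound 3 `COc1ncnc2c1c(I)cn2[C@@H]1O[C@H](CO)[C@@H](O)[C@H]1O` differs from compound 2 by methoxy in place of methylamino on an aromatic carbon. For the measured compounds named here, the single measured step, an at least 1.5-fold higher number from compound 1 to compound 2 (0.20 log units; that floor lies within the scatter), sets methylamino against methyl rather than against methoxy, and it rests on (the limit of > 20000 nM in this assay, at which 1 of the 2 values shown sits). Going by the values given here, no measured step bears directly on this change, so no shift beyond the scatter is expected in this assay. Compound 3 is therefore estimated at 20000 nM, with a range from 8000 nM to 60000 nM, which means an expected step of a number no higher from compound 2 to compound 3 (the limit leaves the size open).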

Compound 3, half-maximal inhibitory concentration: > 20000 nM
Compound 3 ended at the assay's limit (the forecaster's own chance of this, stated with the estimate: 60%); the middle value lies on the limit itself.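

In this assay, compound 3 gives > 20000 nM, which is a limit of the assay and not a number. Methoxy and methylamino at this position therefore both end at a limit, and the step between them cannot be read. Against methyl there is an at least 1.5-fold higher number from compound 1 to compound 3 (0.20 log units; that floor lies within the scatter), so methoxy is not clearly separated from methyl, and the reading of this position rests on little: the limit of > 20000 nM in this assay, at which 2 of the 3 values shown sit. On these data alone, how a plain amine or a longer chain such as ethoxy would read here stays open, as does whether any group at this position gives a number stronger than that of compound 1.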